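Swapping the tert-butyl for chloro on the inactive enantiomer

The source may report more compounds than this note shows. Statements on the series, on what has been measured and on what is new or still open speak of the compounds shown alone.

Three ureas have been tested in an ADME assay on the whole organism with Oryza sativa as the target, tested at 10 uM; a lower number here means a stronger effect, a higher number a weaker effect of the compound at the concentration tested. Compound 1 `C[C@@H](NC(=O)Nc1ccccc1C(C)(C)C)c1ccccc1` gives 17%, the lowest number of the set and thus the strongest effect. Its mirror image, compound 2 `C[C@H](NC(=O)Nc1ccccc1C(C)(C)C)c1ccccc1`, gives 100%, and compound 3 `COc1ccccc1NC(=O)N[C@H](C)c1ccccc1` gives 96%. The change a number 83 percentage points higher from compound 1 to compound 2 (beyond the scatter) shows that the configuration at the chain carbon decides almost everything here, a reading supported by the fact that compounds 1 and 2 differ only in the configuration as drawn. The change a number 79 percentage points higher from compound 1 to compound 3 (beyond the scatter) shows that replacing tert-butyl with methoxy on the aromatic carbon also removes nearly all of the effect.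

Compound 2 therefore stands at the top of the numbers shown: compound 3 sits only a little lower, within the scatter, while compound 1 lies far below it, beyond the scatter.

The next compound, compound 4 `C[C@H](NC(=O)Nc1ccccc1Cl)c1ccccc1`, keeps the configuration of compound 2 and differs from it in one place: chloro in place of tert-butyl on an aromatic carbon. Both earlier steps point the same way. Among the measured compounds shown here, compound 2 already shows almost no effect, and the one change made at this aromatic carbon, from compound 1 to compound 3, only weakened the effect further. A step from compound 2 to compound 4 of a number 5 percentage points lower from compound 2 to compound 4 (within the scatter) is therefore expected, that is, nothing beyond the scatter. Compound 4 is estimated to give 95%, between 75% and 105%.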

Compound 4, a percentage reported as activity, at one concentration (the size of the read-out at that concentration, not a potency): 106%
Estimate against measurement, compound 4: 11 percentage points below; the measured number lies above the stated range.
By their numbers in this assay, from the lowest: compound 1; then compounds 3, 2 and 4 (each within the scatter of the next).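

At this aromatic carbon, in the configuration of compound 2, going from tert-butyl with 4 heavy atoms to chloro with 1 heavy atom gives a number 6 percentage points higher from compound 2 to compound 4 (within the scatter) in this assay, so this large cut in the size of the group leaves no readable change. The earlier change at this carbon looked very different. It was made in the configuration of compound 1 and gave a number 79 percentage points higher from compound 1 to compound 3 (beyond the scatter), so the same position can matter greatly in one configuration and show nothing in the other, at least for these two pairs, which also differ in the incoming group. Compound 4 also shows that a new group here does not bring back the effect in this configuration, which keeps the low number of compound 1 tied to its configuration, as the most direct comparison in the set shows: the fact that compounds 1 and 2 differ only in the configuration as drawn.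

On these data alone, what remains open is whether chloro in the configuration of compound 1 would hold on to the effect, as tert-butyl does, or lose it, as methoxy does. Also open, as far as these compounds go, is how an amine, a carboxylic acid or a longer chain at this aromatic carbon would read in either configuration.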